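Chloro to Methoxy: Two Steps in One Cell Assay

The source may hold more compounds than are shown below. What is called first, only, known or untested is meant among the compounds shown, and "the series" means these compounds.

Compound 1 `O=C(Nc1cc(-c2ccccc2)[nH]n1)c1ccc(Cl)nc1`: 7850 nM
Compound 2 `COc1ccc(C(=O)Nc2cc(-c3ccccc3)[nH]n2)cn1`: 9560 nM
Compound 3 `O=C(Nc1cc(-c2ccc(Br)cc2)[nH]n1)c1cccnc1Cl`: 8220 nM

All three were tested in a functional assay on A-375 cells (Homo sapiens) for antiproliferative activity, read by MTT assay, with a stated time of 48 h; on this read-out higher numbers stand for weaker inhibition and lower numbers for stronger inhibition. Compound 1 and compound 2 differ by one change, (methoxy in place of chloro on an aromatic carbon), and the result was a 1.2-fold higher number from compound 1 to compound 2 (0.09 log units; within the scatter), so the two values cannot be told apart. Compound 3 carries a different core; how its core differs from that of compound 1 is not broken down here, and the values of compound 1 and compound 3 lie close together.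

Compound 4 `COc1ncccc1C(=O)Nc1cc(-c2ccc(Br)cc2)[nH]n1` is not yet measured. It is made from compound 3 by methoxy in place of chloro on an aromatic carbon. Going by the values given here, the change is the same kind as the one from compound 1 to compound 2, but not the same: there the methoxy stands para to a large group, here ortho to a large group. Since the earlier step was a 1.2-fold higher number from compound 1 to compound 2 (0.09 log units; within the scatter), the expected step is a 1.2-fold higher number from compound 3 to compound 4 (0.06 log units; within the scatter), also small. On that basis compound 4 is expected to give 9500 nM, within a range from 5000 nM to 18000 nM.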

Compound 4, half-maximal inhibitory concentration: 11100 nM
The estimate for compound 4 lay 1.2-fold (0.07 log units) below the measured number; the range from low to high includes it.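

In this assay, methoxy in place of chloro on the core of compound 3 gave a 1.4-fold higher number from compound 3 to compound 4 (0.13 log units; within the scatter), so the two values cannot be told apart. The step also agrees with the one seen earlier on the other core, even though the methoxy here sits ortho to a large group and next to the ring nitrogen: the same change on two cores in this assay, a 1.2-fold higher number (0.09 log units; within the scatter) from compound 1 to compound 2 and a 1.4-fold higher number (0.13 log units; within the scatter) from compound 3 to compound 4, 1.1-fold (0.04 log units) apart, within the scatter of two such steps This shows that, in these two pairs, the change carried from one core to the other without a measurable shift in the number, but two steps that each lie within the scatter show only that nothing could be detected, not that the change would behave the same way on any further core or in any other test.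

The compounds shown hold only chloro or methoxy at these carbons, so it remains open whether an amine or a longer chain such as ethoxy would move the number. They also leave open whether any group at these places can produce a step that stands clear of the scatter.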